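The compounds below may be only part of what the source reports. "The series", "measured", "known", "first", "only" and "open" are said of these compounds alone.

Measured so far in an ADME assay on Vero cells (Chlorocebus sabaeus) for cytotoxicity, read by crystal violet staining; a higher number here means that more compound is tolerated, a lower number that less compound is tolerated:
- compound 1 `Clc1cccc(/N=N/N2CCCCC2)c1` gives > 100000 nM (a limit)
- compound 2 `CN1CCN(/N=N/c2cc(F)ccc2F)CC1` gives >= 100000 nM (a limit)
- compound 3 `CN(C)CCCNc1ccc(/N=N/c2c(F)cccc2F)cc1` gives 65000 nM (a number)

Compound 1 has no numerical half-maximal cytotoxic concentration: its entry (> 100000 nM) is a limit of the assay. This is the limit of > 100000 nM in this assay, at which 1 of the 3 values shown sits, and it marks where compound 1 stands. Compound 2 also returns only a limit (>= 100000 nM). Compound 3 is the only one of the three with a number (65000 nM).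

The next compound to be read is compound 4 `O=[N+]([O-])c1cccc(/N=N/N2CCCCC2)c1`, which has nitro in place of chloro on an aromatic carbon of the core of compound 1. The counted change is nitro in place of chloro on an aromatic carbon and it sits on an aromatic carbon of a six-membered aromatic ring of carbon only, meta to a group of 8 heavy atoms.

For the measured compounds named here, no pair of measured compounds differs in one place, so this exchange has no direct precedent. In this assay the expectation is a step no larger than the scatter, leaning if anything towards less compound tolerated. The expected change is an at least 1.2-fold lower number from compound 1 to compound 4 (0.09 log units; that floor lies within the scatter). Compound 4 too may yield only a limit. The estimated value for compound 4 is 80000 nM (expected range 30000 nM to 100000 nM).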

Compound 4, half-maximal cytotoxic concentration: 83000 nM
Beside the measured number, compound 4's estimate is 1.0-fold (0.02 log units) below it; the range from low to high includes it.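

In this assay, for the compounds shown here, the exchange of nitro for chloro on an aromatic carbon of the core of compound 1 gives the only step between compounds that differ in one place: an at least 1.2-fold lower number from compound 1 to compound 4 (0.08 log units; that floor lies within the scatter). Compound 4 gives a number on this core, 83000 nM, so the position meta to a group of 8 heavy atoms can carry nitro and still return a measurable half-maximal cytotoxic concentration. Compound 1 stands at a limit and not at a number, so the step from it has only a floor: the limit of > 100000 nM in this assay, at which 1 of the 4 values shown sits.

On these data alone, that floor lies within the scatter, and whether nitro in place of chloro shifts the tolerated concentration at all, and by how much, stays open. Also open, as far as these compounds go, is how an amine, a carboxylic acid or a nitrile on the same aromatic carbon would read in this assay, and whether the exchange would give a similar step on a core carrying a different group of heavy atoms.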